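A few compounds are considered here, and "the series" means these few. Any claim that something is new, unique, unknown or untested is made for them only; others in the source may bear on it.

Notes on the series. The read-out throughout is an assay on isolated protein with Bile acid receptor (Homo sapiens) as the target; on this read-out lower numbers stand for an effect already at smaller amounts and higher numbers for an effect only at larger amounts of compound. Compound 1 `COC(=O)/C=C/c1cccc(N(Cc2ccc(/C=C/c3scnc3C)cc2)C(=O)C2CCCCC2)c1` gives 227 nM in this assay. Compound 2 `COC(=O)/C=C/c1cccc(N(Cc2ccccc2)C(=O)C2CCCCC2)c1` differs from compound 1 by hydrogen in place of 2-(4-methyl-1,3-thiazol-5-yl)ethenyl on an aromatic carbon. In this assay compound 2 is reported only as a limit, > 1000 nM. The step of an at least 4.4-fold higher number from compound 1 to compound 2 (0.64 log units; beyond the scatter) thus rests on one measured value and one limit (the limit of > 1000 nM in this assay, at which 1 of the 2 values shown sits), and compound 2 stands at the weaker end of the two values shown.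

Compound 3 `COC(=O)/C=C/c1cccc(N(Cc2ccc(/C=C/C(=O)NC(C)(C)C)cc2)C(=O)C2CCCCC2)c1` is the next member. Against compound 2 the change is 2-((tert-butyl)carbamoyl)ethenyl in place of hydrogen on an aromatic carbon. For the measured compounds named here, the one measured step that bears on it is an at least 4.4-fold higher number from compound 1 to compound 2 (0.64 log units; beyond the scatter), where removal of an ethenyl-linked group from the same aromatic carbon cost at least a modest amount. Going by the values given here, putting an ethenyl-linked group back on that carbon is therefore expected to lower the number in this assay, although the group entering here is not the one that left in compound 2, so the size is uncertain. For compound 3 the expected step is an at least 2.5-fold lower number from compound 2 to compound 3 (0.39 log units; beyond the scatter). Compound 3 is estimated at 400 nM in this assay, with a range from 120 nM to 1500 nM.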

Compound 3, half-maximal effective concentration: > 1000 nM
Compound 3: no number, only a limit; the forecaster's own chance of this, stated with the estimate: 25%; at least 2.5-fold (0.39 log units) between middle value and limit.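

With the ethenyl link kept and only the group at its end exchanged, (tert-butyl)carbamoyl in place of 4-methyl-1,3-thiazol-5-yl, this assay gives an at least 4.4-fold higher number from compound 1 to compound 3 (0.64 log units; beyond the scatter), so among these compounds the ethenyl link alone does not secure a measured number. At this position, para to a large group, the identity of the group on the chain therefore matters, and not only whether a chain is present, with compound 1 the only one of the three that has a number rather than a limit. Compound 2 and compound 3 are both reported only as limits, so the step between them cannot be read and any difference between hydrogen and the new chain stays hidden: the limit of > 1000 nM in this assay, at which 2 of the 3 values shown sit.

Going by these compounds, it remains open whether the number of compound 1 depends on the whole 4-methyl-1,3-thiazol-5-yl group or on its methyl group, which a 1,3-thiazol-5-yl or a phenyl group on the same chain carbon would help to separate. Also open, on these data alone, are whether a saturated ethyl link would serve in place of the ethenyl link and whether a carboxylic acid at the chain end would return a number.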